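Trifluoromethyl on compound 1: what growth inhibition to expect

The source may report more compounds than this note shows. Statements on the series, on what has been measured and on what is new or still open speak of the compounds shown alone.

Compound 1 `Nc1c(C(=O)Nc2ccccc2)sc2nc3c(cc12)CCCCCC3`: 217 nM
Compound 2 `Nc1c(C(=O)Nc2ccccc2Cl)sc2nc3c(cc12)CCCCCC3`: 2650 nM

Among the compounds with values here, in a functional assay on SF-539 cells (Homo sapiens) for cytotoxicity, read by sulforhodamine B assay, with a stated time of 48 h (on this read-out higher numbers stand for weaker inhibition of growth and lower numbers for stronger inhibition of growth), compound 1 gives 217 nM, the lowest of the two numbers so far. Compound 3 `Nc1c(C(=O)Nc2cccc(C(F)(F)F)c2)sc2nc3c(cc12)CCCCCC3` has not yet been measured. It differs from compound 1 by one change: trifluoromethyl in place of hydrogen on an aromatic carbon. In words, this is trifluoromethyl in place of hydrogen on an aromatic carbon, meta to a large group.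

Within the data shown here, the only measured step that bears on this is chloro in place of hydrogen on an aromatic carbon, a 12-fold higher number from compound 1 to compound 2 (1.09 log units; beyond the scatter), which is large. A higher number is therefore expected in this assay for the new substitution as well. Chloro and trifluoromethyl are different groups, and a single step cannot show how far the trend carries, so a smaller step is expected. The estimated step is a 3.0-fold higher number from compound 1 to compound 3 (0.48 log units; beyond the scatter). For compound 3 the estimated value is 650 nM, with an expected range from 170 nM to 2500 nM.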

Compound 3, concentration for 50% growth inhibition: 1710 nM
For compound 3 the middle estimate is 2.6-fold (0.42 log units) below the measured one; measured number inside the range.
By their numbers in this assay, from the lowest: compound 1; then compounds 3 and 2 (each within the scatter of the next).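

In this assay, trifluoromethyl on an aromatic carbon, meta to a large group, gives a 7.9-fold higher number from compound 1 to compound 3 (0.90 log units; beyond the scatter) and so adds a second substitution that weakens growth inhibition. Set beside a 12-fold higher number from compound 1 to compound 2 (1.09 log units; beyond the scatter), this shows that the rise in the number is not confined to chloro: both substitutions shown move away from compound 1, which keeps the lowest number, and neither goes against this pattern. Nothing measured here accounts for the size of either step.

The compounds shown leave open whether any group at this place could match or improve on the hydrogen of compound 1, for instance an amine, a hydroxyl group or a carboxylic acid. They also leave open how a group such as methoxy would fare on other carbons of the same six-membered aromatic ring.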